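Flipping a single stereocentre: from compound 3 to compound 4

The compounds below may be only part of what the source reports. "The series", "measured", "known", "first", "only" and "open" are said of these compounds alone.

Three thiourea-linked compounds sharing one core have been measured in a functional assay on MCF7 cells (Homo sapiens) for cytotoxicity, read by MTT assay; a higher number here means a weaker inhibitor, a lower number a stronger inhibitor. Compound 1 `CC(C)C[C@@H](NC(=S)NCc1ccccc1)c1nc2ccccc2[nH]1` gives 18200 nM. Compound 2 `CC(C)[C@@H](NC(=S)Nc1ccccc1)c1nc2ccccc2[nH]1` is reported in this assay as "not active" (no number reported), with no number attached. Compound 3 `CC(C)[C@H](NC(=S)NCc1ccccc1)c1nc2ccccc2[nH]1` gives 57800 nM, which is the highest of the two numbers shown, standing a step beyond the usual scatter above compound 1.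

The next compound, compound 4 `CC(C)[C@@H](NC(=S)NCc1ccccc1)c1nc2ccccc2[nH]1`, is not yet measured. Against compound 3 the change is the two compounds have the same atoms and bonds and differ only in configuration as drawn: 1 of 1 stereo elements differ; a stereocentre at a saturated chain carbon is drawn S in compound 3 and R in compound 4. Among the compounds with values here, no pair of measured compounds shows this kind of change on its own, so its effect here is unknown. Compound 1 carries the same drawn configuration as compound 4 while differing in its side chain, and the step from compound 3 to compound 1 is the closest guide available.

Compound 4 is therefore expected to fall near compound 1 rather than near compound 3, the expected step being a 2.3-fold lower number from compound 3 to compound 4 (0.36 log units; beyond the scatter) in this assay. The estimate for compound 4 in this assay is 25000 nM, with a range from 8000 nM to 80000 nM, with the wide range reflecting that a change of configuration alone can move a number in either direction.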

Compound 4, half-maximal inhibitory concentration: 11100 nM
Beside the measured number, compound 4's estimate is 2.3-fold (0.35 log units) above it; measured number inside the range.
By their numbers in this assay, from the lowest: compounds 4 and 1 (each within the scatter of the next); then compound 3.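

In this assay, changing the drawn configuration at this saturated chain carbon from S to R gives a 5.2-fold lower number from compound 3 to compound 4 (0.72 log units; beyond the scatter), so the spatial arrangement at this one carbon shifts the reading by more than the usual scatter of repeat measurements. Nothing else can account for this step, because no atom or bond changes between the two compounds: the fact that compounds 3 and 4 differ only in the configuration as drawn. With the configuration drawn the same, isopropyl in place of isobutyl on this carbon gives a 1.6-fold lower number from compound 1 to compound 4 (0.21 log units; within the scatter), so these two side chains cannot be told apart in this assay, and the choice of configuration moves the number more clearly than this change of side chain does.

The compounds shown include no partner of compound 1 with the opposite configuration, so it remains open whether a flip at this carbon would have a similar effect with the isobutyl chain. Within the data shown here, it is also unknown how a longer chain, or an amine or carboxylic acid on the side chain, would behave at this position in either configuration, and the single pair of compounds 3 and 4 cannot show whether the preference for R holds beyond this one side chain.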